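Methylation of the naphthol oxygen in compound 2

The source may hold more compounds than are shown below. What is called first, only, known or untested is meant among the compounds shown, and "the series" means these compounds.

Measured compounds:
- compound 1 `COc1cc(CC2C(C#N)=C(N)N(c3ccc(S(N)(=O)=O)cc3)C3=C2C(=O)CCC3)ccc1O`: 90%
- compound 2 `N#CC1=C(N)N(c2ccc(S(N)(=O)=O)cc2)C2=C(C(=O)CCC2)C1c1c(O)ccc2ccccc12`: 5%

In a functional assay on Ehrlich cells (Mus musculus) for antiproliferative activity, read by trypan blue exclusion, with a stated time of 2 h, tested at 50 ug/mL (on this read-out lower numbers stand for a weaker effect and higher numbers for a stronger effect at the one concentration tested), compound 1 gives 90%, and compound 2 gives 5%, the lowest of the two numbers shown. For the measured compounds named here, the one step available, a number 85 percentage points lower from compound 1 to compound 2 (beyond the scatter), replaces 4-hydroxy-3-methoxybenzyl with 2-hydroxynaphthalen-1-yl on a saturated ring carbon of the shared core.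

Compound 3 `COc1ccc2ccccc2c1C1C(C#N)=C(N)N(c2ccc(S(N)(=O)=O)cc2)C2=C1C(=O)CCC2` differs from compound 2 by methyl in place of hydrogen on an oxygen on an aromatic ring. Going by the values given here, no measured pair reports this change, hydroxy to methoxy on the naphthyl group, so the large step from compound 1 to compound 2 does not bear on it directly; it only shows that the aryl substituent region matters for this assay. With compound 2 already near the bottom of the scale, a step downward beyond the scatter is hardly possible, and compound 3 is expected to show a number 5 percentage points higher from compound 2 to compound 3 (within the scatter), a change within the scatter. Compound 3 is therefore estimated at 10%, within 0% to 40%.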

Compound 3, a percentage reported as activity, at one concentration (the size of the read-out at that concentration, not a potency): 70%
For compound 3 the middle estimate is 60 percentage points below the measured one; the whole stated range lies below it.
By their numbers in this assay, from the lowest: compound 2; then compound 3; then compound 1.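

In this assay methyl in place of hydrogen on the naphthol oxygen gives a number 65 percentage points higher from compound 2 to compound 3 (beyond the scatter) and thus shows that this single oxygen substituent decides much of the read-out, so the naphthyl group alone does not bring the low number seen for compound 2. Against 4-hydroxy-3-methoxybenzyl, the 2-methoxynaphthalen-1-yl group gives a number 20 percentage points lower from compound 1 to compound 3 (beyond the scatter) and so keeps much of the effect that the hydroxy form had appeared to lose. Nothing available explains why the methyl group has so large an effect on this read-out.

The compounds shown leave open whether the effect is specific to methyl or would persist with an ethyl group, a longer chain or an acetyl group on this oxygen. They also leave open how an amine in place of the methoxy group would read.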